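This account rests on a few compounds, and the source may have more. Where it says the series, first, only, none or still open, it means among the compounds named here.

Working notes on the series.

Three compounds carry a measurement. Compound 1 `CN(Cc1ccc(OCCCN)cc1)c1nc2ccc(Oc3ccccc3)cc2s1` gives 95000 nM in an assay on cells for inhibition of Voltage-dependent T-type calcium channel subunit alpha-1H (Homo sapiens), read by FLIPR and calcium flux, with stated times of 600 s and 300 s; a lower number here means a stronger inhibitor, a higher number a weaker inhibitor. Compound 2 `CN(Cc1ccc(OCCCN)cc1)c1nc2ccc(Oc3ccc(C(F)(F)F)cc3)cc2s1` differs from compound 1 by trifluoromethyl in place of hydrogen on an aromatic carbon. In this assay compound 2 gives 248000 nM, a step of a 2.6-fold higher number from compound 1 to compound 2 (0.42 log units; beyond the scatter). Compound 3 `CN(Cc1ccc(OCCCNC(=N)N)cc1)c1nc2ccc(Oc3ccccc3)cc2s1` differs from compound 1 by a group of 3 heavy atoms (1 carbon, 2 nitrogen; no ring) in place of a hydrogen atom, on an amine nitrogen. In this assay compound 3 gives 498000 nM, a step of a 5.2-fold higher number from compound 1 to compound 3 (0.72 log units; beyond the scatter). Among the compounds with values here, compound 2 and compound 3 have no counted step between them; their two numbers sit within the scatter of each other, so nothing is said of their order.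

Compound 4 `CN(Cc1ccc(OCCCNC(=N)N)cc1)c1nc2ccc(Oc3cccc(C(F)(F)F)c3)cc2s1` is not yet measured. It differs from compound 3 by trifluoromethyl in place of hydrogen on an aromatic carbon. Within the data shown here, this is the same kind of change as the one from compound 1 to compound 2, but not the same: there the entering group stands para to a large group, here it stands meta to a large group. The two cores differ as described by a group of 3 heavy atoms (1 carbon, 2 nitrogen; no ring) in place of a hydrogen atom, on an amine nitrogen, so the change is read against the core of compound 3 rather than that of compound 1.

Among the measured compounds shown here, from compound 3 to compound 4 a step of about a 2.0-fold higher number from compound 3 to compound 4 (0.30 log units; within the scatter) is expected, set beside the measured 2.6-fold higher number from compound 1 to compound 2 (0.42 log units; beyond the scatter), since the only measured instance of this kind of change moved the number by that amount; the different place of the entering group adds uncertainty. For compound 4 the expected value in this assay is 1000000 nM, with a range from 400000 nM to 3000000 nM.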

Compound 4, half-maximal inhibitory concentration: 771000 nM
Compound 4: middle estimate off by 1.3-fold (0.11 log units), on the high side; measured number inside the range.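

In this assay the new step reads a 1.5-fold higher number from compound 3 to compound 4 (0.19 log units; within the scatter), so no order is claimed between compound 3 and compound 4. Set beside the earlier instance of trifluoromethyl in place of hydrogen, this step gives no sign that the two cores respond differently: the same change on two cores in this assay, a 2.6-fold higher number (0.42 log units; beyond the scatter) from compound 1 to compound 2 and a 1.5-fold higher number (0.19 log units; within the scatter) from compound 3 to compound 4, 1.7-fold (0.23 log units) apart, within the scatter of two such steps. This fits a change that carries from one core to the other, but it does not prove that it does: there are only two instances, one of them is within the scatter, and the entering group stands meta to a large group in compound 4 but at a different place in compound 2, so any influence of the core cannot be separated from that of position.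

The compounds shown leave open whether trifluoromethyl at a single place would read the same on both cores, and whether other groups on the outer aromatic ring, such as a chlorine atom, a methoxy group or a nitrile, would follow the same course. Also open, going by these compounds, is how the number would respond at the far end of the chain to a carboxylic acid, an amide or a longer chain carrying the same amine.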